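Amino to Chloro on a Saturated Chain Carbon

The source may report more compounds than this note shows. Statements on the series, on what has been measured and on what is new or still open speak of the compounds shown alone.

Of the compounds shown here, two that share one core have been measured in a functional assay on HeLa cells (Homo sapiens) for inhibition, read by MTT assay, with a stated time of 72 h; on this read-out higher numbers stand for weaker inhibition and lower numbers for stronger inhibition. Compound 1 `N[C@H](CSCC(=O)Nc1c[nH]c(=O)[nH]c1=O)C(=O)O` gives 86000 nM in this assay. Compound 2 `NCC(=O)Nc1c[nH]c(=O)[nH]c1=O` reaches only the limit of this assay, > 100000 nM, so no number is known for it. The record for compound 2 is therefore (the limit of > 100000 nM in this assay, at which 1 of the 2 values shown sits). Compound 3 `O=C(CCl)Nc1c[nH]c(=O)[nH]c1=O` has not yet been measured. It differs from compound 2 in one place: chloro in place of amino on a saturated chain carbon bound to a carbonyl carbon. No step between two measured compounds is shown, so there is nothing to rest a prediction on beyond the two values above. Compound 2 sits only at a limit; the size of any step from it cannot be read from the data, and one can only expect that compound 3 might register within the working range of this assay. The expected step from compound 2 to compound 3 is an at least 1.6-fold lower number from compound 2 to compound 3 (0.22 log units; that floor lies within the scatter). Compound 3 is estimated at 60000 nM, with a range from 15000 nM to 150000 nM, and a real chance that this assay again reports only a limit.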

Compound 3, half-maximal inhibitory concentration: 4000 nM
Estimate against measurement, compound 3: 15-fold (1.18 log units) above, outside the stated range (below it).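

In this assay, the exchange of a single heavy atom on a saturated chain carbon bound to a carbonyl carbon gives an at least 25-fold lower number from compound 2 to compound 3 (1.39 log units; beyond the scatter). This shows that the position is not indifferent to what it carries: on the same shared core, amino and chloro are far apart, and the change alone brings the series clearly into the working range of the measurement. The step is a floor and not an exact size, since the value for compound 2 is only a limit: the limit of > 100000 nM in this assay, at which 1 of the 3 values shown sits.

What the compounds shown leave open is why this change matters so much, as a single exchange cannot separate what is lost with the amino group from what is gained with the chloro group. Among these compounds, a hydroxyl, a methyl or a bromo group on the same saturated chain carbon would help to show whether the lower number is seen only with chloro or also with other groups in place of amino.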